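A Sulfonamide Change Against a Background of Limits

A few compounds are considered here, and "the series" means these few. Any claim that something is new, unique, unknown or untested is made for them only; others in the source may bear on it.

Compound 1 `O=S(=O)(Nc1ccc2oc(-c3ccccc3)nc2c1)c1ccc(O)cc1` and compound 2 `Cc1ccc(S(=O)(=O)Nc2ccc(-c3nc4ccccc4o3)cc2)cc1` are two sulfonamides tested in an assay on isolated protein for inhibition of malate dehydrogenase, mitochondrial (Sus scrofa), with stated times of 45 min and 30 min; a higher number here means a weaker inhibitor, a lower number a stronger inhibitor. Compound 1 gives in this assay only a limit, > 63000 nM. Compound 2 likewise gives only a limit in this assay, > 63000 nM. On the numbers shown, compound 1 has no measured position of its own: the limit of > 63000 nM in this assay, at which 2 of the 2 values shown sit, so no step between measured compounds can be read from this pair. Compound 3 `COc1ccc(Cl)cc1S(=O)(=O)Nc1ccc2oc(-c3ccccc3)nc2c1` has not yet been tested in this assay. It differs from compound 1 in one place: 5-chloro-2-methoxyphenyl in place of 4-hydroxyphenyl on a sulfonyl sulfur. For the measured compounds named here, no measured pair here speaks to that change, and with both known values sitting at a limit, no direction can be taken from them. Compound 3 is expected to stay weak, with an estimated step of an at least 1.2-fold lower number from compound 1 to compound 3 (0.10 log units; that floor lies within the scatter) that would be at most a modest gain. The estimate for compound 3 in this assay is 50000 nM, between 10000 nM and 200000 nM.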

Compound 3, half-maximal inhibitory concentration: > 63000 nM
Compound 3: only a limit was reported (the forecaster's own chance of this, stated with the estimate: 70%); at least 1.2-fold (0.10 log units) between middle value and limit.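

Compound 3, like compound 1, gives only a limit, so no step between compound 1 and compound 3 can be read in this assay: the limit of > 63000 nM in this assay, at which 3 of the 3 values shown sit.

The compounds shown leave open whether 5-chloro-2-methoxyphenyl in place of 4-hydroxyphenyl on a sulfonyl sulfur changes inhibition at all, and what actual value compound 1, compound 2 or compound 3 would have.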